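Dipropylamino in Place of (3-Methoxyphenyl)amino on a Shared Core

A few compounds are considered here, and "the series" means these few. Any claim that something is new, unique, unknown or untested is made for them only; others in the source may bear on it.

Two compounds have been measured in a functional assay on ECa-109 cells for inhibition, with ECa-109 cell line (Homo sapiens) as the target, read by sulforhodamine B assay; a lower number here means a stronger inhibitor, a higher number a weaker inhibitor:

compound 1, `COc1cccc(NC2=CC(=O)c3c(nc4n3[C@H]3OC[C@@H](O)[C@H]3OC4)C2=O)c1`, gives 3340 nM
compound 2, `O=C1C=C(Nc2ccc(Br)cc2)C(=O)c2c1nc1n2[C@H]2OC[C@@H](O)[C@H]2OC1`, gives 2850 nM

Compound 1 holds the higher of the two numbers, yet compound 2 sits within the scatter of it, so the two cannot be told apart in this assay. Neither compound reaches strong inhibition; both lie in the micromolar region.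

Compound 3, `CCCN(CCC)C1=CC(=O)c2c(nc3n2[C@H]2OC[C@@H](O)[C@H]2OC3)C1=O`, has not yet been measured. It differs from compound 1 in one place: dipropylamino in place of (3-methoxyphenyl)amino on a double-bonded ring carbon. For the measured compounds named here, no measured pair in this set shows what such a swap of an aromatic amine for an aliphatic one does on this core, so the direction of the step is open. Given the flat picture between compound 1 and compound 2, the step from compound 1 to compound 3 is expected to be modest, a 1.6-fold higher number from compound 1 to compound 3 (0.22 log units; within the scatter), leaning toward weaker inhibition. Compound 3 is therefore estimated at 5500 nM, with a plausible range from 1800 nM to 17000 nM.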

Compound 3, half-maximal inhibitory concentration: > 16000 nM
Compound 3 ended at the assay's limit; the forecaster's own chance of this, stated with the estimate: 10%; middle value at least 2.9-fold (0.46 log units) away from the limit.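

Compound 1 and compound 2 both carry an aromatic amine on the double-bonded ring carbon, so only compound 3 tests this place without one, and in this assay the change is not neutral: dipropylamino in place of (3-methoxyphenyl)amino gives an at least 4.7-fold higher number from compound 1 to compound 3 (0.68 log units; beyond the scatter). Compound 3 gives > 16000 nM, which is a limit of the assay and not a number. The step is therefore a lower bound, and its true size stays unknown: the limit of > 16000 nM in this assay, at which 1 of the 3 values shown sits.

The swap removes the aromatic ring and the hydrogen-bond donor on the amine nitrogen together, and the compounds shown do not tell these two changes apart. Where propylamino, which keeps that donor without the ring, or benzylamino, which keeps both, would fall in this assay stays open.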